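A few compounds are considered here, and "the series" means these few. Any claim that something is new, unique, unknown or untested is made for them only; others in the source may bear on it.

Measured so far in a physicochemical assay, read by spectrophotometry, with a stated time of 30 min; on this read-out higher numbers stand for weaker inhibition and lower numbers for stronger inhibition:

- compound 1 `O=C(CCc1nc2ccccc2c(=O)[nH]1)N/N=C/c1ccc(O)cc1` gives 238000000 nM
- compound 2 `O=C(CCCc1nc2ccccc2c(=O)[nH]1)N/N=C/c1cc(O)c(O)c(O)c1` gives 78000000 nM
- compound 3 `COc1cc(/C=N/NC(=O)CCc2nc3ccccc3c(=O)[nH]2)ccc1O` gives 204000000 nM

Compound 2 has the lowest number of the three, and the values of compound 3 and compound 1 both lie above it, beyond the scatter. The next compound to consider is compound 4 `O=C(CCCc1nc2ccccc2c(=O)[nH]1)N/N=C/c1ccc(O)c(O)c1`, not yet measured. The change is hydrogen in place of hydroxy on an aromatic carbon, which turns 3,4,5-trihydroxyphenyl into 3,4-dihydroxyphenyl.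

For the measured compounds named here, no measured step removes a hydroxy. Going by the values given here, the only single-place step is a 1.2-fold lower number from compound 1 to compound 3 (0.07 log units; within the scatter) (methoxy in place of hydrogen), a different change that stays within the scatter. Compound 1 and compound 3 carry fewer hydroxy groups than compound 2 but also differ from it in more than one place, so their gap cannot be assigned to the hydroxy alone. They still justify a slight lean towards a higher number, with compound 1 at 238000000 nM and compound 3 at 204000000 nM as the only support. The expected step is a 1.3-fold higher number from compound 2 to compound 4 (0.11 log units; within the scatter) and it would stay within the scatter. The estimate for compound 4 is 100000000 nM with an expected range from 45000000 nM to 210000000 nM in this assay.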

Compound 4, half-maximal inhibitory concentration: 95000000 nM
For compound 4 the middle estimate is 1.1-fold (0.02 log units) above the measured one; the measured number falls inside the stated range.
By their numbers in this assay, from the lowest: compounds 2 and 4 (each within the scatter of the next); then compounds 3 and 1 (each within the scatter of the next).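

In this assay, for the compounds shown here, this is the first step that removes a hydroxy rather than adding a methoxy: going from 3,4,5-trihydroxyphenyl to 3,4-dihydroxyphenyl gives a 1.2-fold higher number from compound 2 to compound 4 (0.09 log units; within the scatter). At this place, on an aromatic carbon ortho to a hydroxy group and meta to a large group, compound 2 and compound 4 cannot be told apart on this read-out, so the third hydroxy is not shown to matter in this pair. Nothing measured in the series speaks to the reason for this outcome.

Going by these compounds alone, the gap between compound 2 or compound 4 and compound 1 or compound 3 remains unassigned, since those compounds differ in more than one place and no single-place step separates the number of hydroxy groups from the chain joining the shared core to the hydrazone. Also open, from the compounds shown here alone, is whether this place accepts anything other than hydrogen or hydroxy, such as an amine or a carboxylic acid, and whether removing a second hydroxy from 3,4-dihydroxyphenyl would give a step beyond the scatter.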